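Amide variants on a shared core: cytotoxicity on liver cells

This account rests on a few compounds, and the source may have more. Where it says the series, first, only, none or still open, it means among the compounds named here.

Measured so far in a functional assay on QGY7701 cells (Homo sapiens) for cytotoxicity, read by MTT assay, with a stated time of 24 h; a lower number here means a stronger inhibitor, a higher number a weaker inhibitor:
- compound 1 `C=CC1=C(C(=O)O)C(c2ccc(OC)cc2)OC1` gives > 100000 nM, a limit of the assay.
- compound 2 `C=CC1=C(C(=O)NC(C)(C)C)C(c2ccc(OC)cc2)OC1` gives > 100000 nM, a limit of the assay.
- compound 3 `C=CC1=C(C(=O)NC(C)(C)C)C(c2ccc(F)cc2)OC1` gives > 100000 nM, a limit of the assay.

Compound 2 thus stands only at a limit in this assay, as do the two other values shown, which is summed up by the limit of > 100000 nM in this assay, at which 3 of the 3 values shown sit. Compound 4 `C=CC1=C(C(=O)NCc2ccc(Cl)cc2)C(c2ccc(OC)cc2)OC1` differs from compound 2 by 4-chlorobenzyl in place of tert-butyl on an amide-type nitrogen. The two measured steps that touch compound 2, a step that the two limits leave unreadable from compound 1 to compound 2 and a step that the two limits leave unreadable from compound 2 to compound 3, are both unreadable in size, since each end sits at the limit. No change beyond the scatter can therefore be expected, and the step of a number no higher from compound 2 to compound 4 (the limit leaves the size open) is estimated to leave compound 4 at the same limit. Compound 4 is expected at 100000 nM, within 30000 nM to 300000 nM.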

Compound 4, half-maximal inhibitory concentration: > 100000 nM
Compound 4 ended at the assay's limit (the forecaster's own chance of this, stated with the estimate: 70%); the middle value lies on the limit itself.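

Compound 2 and compound 4 both sit at a limit in this assay, so the change from tert-butyl to 4-chlorobenzyl gives no readable step. The compounds shown leave open whether any substitution on the shared core gives a measurable potency in this cell line: the limit of > 100000 nM in this assay, at which 4 of the 4 values shown sit.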